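This account rests on a few compounds, and the source may have more. Where it says the series, first, only, none or still open, it means among the compounds named here.

Compound 1 `CC#C[C@H]1CN(S(=O)(=O)c2ccc(N)nc2)CCN1c1ccc(S(N)(=O)=O)cc1` is the reference point. In an assay on cells (Hepatocyte) for inhibition of glucokinase regulatory protein (Mus musculus), with stated times of 20 min and 40 min (a lower number here means that less compound is needed, a higher number that more compound is needed for the effect), compound 1 gives 37 nM, the lowest of the three numbers shown. Compound 2 `CC#C[C@H]1CN(S(=O)(=O)c2ccc(N)nc2)CCN1c1ccc(S(=O)(=O)NCC2CC2)cc1` gives 271 nM, and compound 3 `CC#CCC(O)(c1ccc(N2CCN(S(=O)(=O)c3ccc(N)nc3)C[C@@H]2C#CC)cc1)C(F)(F)F` gives 137 nM. The new compound 4 `CC#C[C@H]1CN(S(=O)(=O)c2ccc(N)nc2)CCN1c1ccc([S+](C)[O-])cc1` differs from compound 1 at a single place: a group of 3 heavy atoms (1 carbon, 1 oxygen, 1 sulfur; no ring) in place of a group of 4 heavy atoms (1 nitrogen, 2 oxygen, 1 sulfur; no ring), on an aromatic carbon. Going by the values given here, two measured steps touch the same position. The step of a 7.3-fold higher number from compound 1 to compound 2 (0.86 log units; beyond the scatter) and the step of a 3.7-fold higher number from compound 1 to compound 3 (0.57 log units; beyond the scatter) both move the number upward once the sulfamoyl is altered or replaced, so a similar modest rise is expected here, though neither step is the same change. Compound 4 is therefore expected to give 150 nM, with a likely range from 50 nM to 500 nM, meaning an estimated step of a 4.1-fold higher number from compound 1 to compound 4 (0.61 log units; beyond the scatter).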

Compound 4, half-maximal effective concentration: > 12500 nM
Compound 4 was reported as a limit; the forecaster's own chance of this, stated with the estimate: 5%; middle value at least 83-fold (1.92 log units) from the limit.
By their numbers in this assay, from the lowest: compound 1; then compounds 3 and 2 (each within the scatter of the next). At a limit, above all of these: compound 4.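

In this assay, compound 4 is reported only as a limit, not a number: the limit of > 12500 nM in this assay, at which 1 of the 4 values shown sits. The steps to it are all large: an at least 330-fold higher number from compound 1 to compound 4 (2.52 log units; beyond the scatter), an at least 91-fold higher number from compound 3 to compound 4 (1.96 log units; beyond the scatter) and an at least 46-fold higher number from compound 2 to compound 4 (1.66 log units; beyond the scatter). Larger groups at this place shifted the number only modestly or less, so this position is more demanding than the earlier compounds showed, and the smaller group here, with no hydrogen-bond donor, does far worse.

The compounds shown leave open whether the missing donor or another feature of the group accounts for this. A simple amine or a carboxylic acid at this place could help separate these possibilities.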